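Homologation of the hydroxycyclohexyl amine on the shared core

The source may report more compounds than this note shows. Statements on the series, on what has been measured and on what is new or still open speak of the compounds shown alone.

Going by the values given here, compound 3 `N#Cc1cnc(NCc2cnccc2C(F)(F)F)cc1N[C@H]1CC[C@@H](O)CC1` gives 100 nM in an assay on isolated protein for inhibition of protein kinase C theta type (Homo sapiens), read by TR-FRET, with a stated time of 2 h (on this read-out higher numbers stand for weaker inhibition and lower numbers for stronger inhibition), the lowest of the three numbers measured so far: compound 2 `N#Cc1cnc(NCc2cnccc2C(F)(F)F)cc1NC[C@H]1C[C@@H](O)C1` gives 300 nM and compound 1 `N#Cc1cnc(NCc2cnccc2C(F)(F)F)cc1N[C@H]1C[C@@H](O)C1` gives 500 nM. The steps into compound 3 read a 3.0-fold lower number from compound 2 to compound 3 (0.48 log units; beyond the scatter) and a 5.0-fold lower number from compound 1 to compound 3 (0.70 log units; beyond the scatter). Compound 4 `N#Cc1cnc(NCc2cnccc2C(F)(F)F)cc1NC[C@H]1CC[C@@H](O)CC1` differs from compound 3 by (4-hydroxycyclohexyl)methyl in place of 4-hydroxycyclohexyl on a nitrogen on an aromatic ring. Among the compounds with values here, the only measured step of the same kind is a 1.7-fold lower number from compound 1 to compound 2 (0.22 log units; within the scatter), which did not leave the scatter. Inserting the methylene is therefore expected to move this assay little, with no clear direction and at most a small lowering of the number. For compound 4 the estimate in this assay is 80 nM, with a range of 30 nM to 250 nM. This is expected to amount to a 1.3-fold lower number from compound 3 to compound 4 (0.10 log units; within the scatter).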

Compound 4, half-maximal inhibitory concentration: 58 nM
The estimate for compound 4 lay 1.4-fold (0.14 log units) above the measured number, and the stated range covers the measured number.
By their numbers in this assay, from the lowest: compounds 4 and 3 (each within the scatter of the next); then compounds 2 and 1 (each within the scatter of the next).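

On the cyclohexyl ring the added methylene gives a 1.7-fold lower number from compound 3 to compound 4 (0.24 log units; within the scatter) so on both ring sizes this change stays inside the scatter. The change from 3-hydroxycyclobutyl to 4-hydroxycyclohexyl still reads with the methylene in place, as a 5.2-fold lower number from compound 2 to compound 4 (0.71 log units; beyond the scatter) and the two changes together give an 8.6-fold lower number from compound 1 to compound 4 (0.94 log units; beyond the scatter) so in this assay the ring, not the methylene, separates compound 1 and compound 2 from compound 3 and compound 4. As far as these compounds go, whether an amine in place of the hydroxyl on the cyclohexyl ring, or a longer chain in place of the methylene, would keep these numbers stays open. Nothing on hand explains these steps.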